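This account rests on a few compounds, and the source may have more. Where it says the series, first, only, none or still open, it means among the compounds named here.

Working notes on the series. Compound 1 `C=C(C/C(=C\c1ccccc1)C(=O)c1ccccc1)C(=O)c1ccccc1` and compound 2 `C=C(C/C(=C\c1ccc(Cl)cc1)C(=O)c1ccccc1)C(=O)c1ccccc1` share one core and differ only at one aromatic carbon. In a functional assay on HBL-100 cells (Homo sapiens) for inhibition, read by sulforhodamine B assay, with a stated time of 48 h (on this read-out higher numbers stand for weaker inhibition of growth and lower numbers for stronger inhibition of growth), compound 1 gives 10000 nM, and compound 2 gives 17000 nM. Among the compounds with values here, the one step measured so far, a 1.7-fold higher number from compound 1 to compound 2 (0.23 log units; within the scatter), puts chloro in place of hydrogen and moves the number by an amount that cannot be separated from noise. Compound 2 therefore carries the highest of the two numbers, with compound 1 as its nearest neighbour, but the two values cannot be ranked against each other.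

Compound 3 `C=C(C/C(=C\c1ccc(F)cc1)C(=O)c1ccccc1)C(=O)c1ccccc1` is the next member to be measured. The change from compound 2 is fluoro in place of chloro on an aromatic carbon. Within the data shown here, the only step that bears on it is the one from compound 1 to compound 2, which is itself within the scatter, so no shift beyond the scatter is expected from exchanging one halogen for another at the same aromatic carbon in this assay. The expected step of a 1.3-fold lower number from compound 2 to compound 3 (0.12 log units; within the scatter) is accordingly small, with a slight lean toward the number of compound 1. Compound 3 is estimated at 13000 nM, within 6000 nM to 30000 nM.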

Compound 3, concentration for 50% growth inhibition: 14000 nM
Compound 3: middle estimate off by 1.1-fold (0.03 log units), on the low side; the measured number falls inside the stated range.
By their numbers in this assay, from the lowest: compounds 1, 3 and 2 (each within the scatter of the next).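

In this assay the second halogen adds a new reading at this aromatic carbon, para to a large group: the change from 4-chlorophenyl to 4-fluorophenyl gives a 1.2-fold lower number from compound 2 to compound 3 (0.08 log units; within the scatter) and fluoro in place of hydrogen gives a 1.4-fold higher number from compound 1 to compound 3 (0.15 log units; within the scatter) so that both steps lie within the scatter. Together with the earlier chloro step, this means that hydrogen, fluoro and chloro at this carbon cannot be told apart on this read-out, and the three compounds form a single group with no order among them. The position has so far tolerated each of these exchanges without a measurable shift, although no data bear on why, and nothing available accounts for this result.

The compounds shown leave open whether a larger or differently built substituent at this aromatic carbon, such as an amine, a methoxy group or a carboxylic acid, would move the number beyond the scatter. They also leave open whether any change on the other aromatic rings or in the chain of the shared core would do so, since every compound here differs only at this one carbon.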